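Amide variation on the shared core: carboxyethyl to tetrazolyl

This account rests on a few compounds, and the source may have more. Where it says the series, first, only, none or still open, it means among the compounds named here.

compound 1 `O=C(O)c1ccc(Cn2nc(C3CCCCC3)cc2-c2ccc(OC(F)(F)F)cc2)cc1`: 4100 nM
compound 2 `O=C(O)CCNC(=O)c1ccc(Cc2cn(-c3ccc(OC(F)(F)F)cc3)nc2C2CCCCC2)cc1`: 7400 nM

In a functional assay on CHO cells for antagonist activity at gastric inhibitory polypeptide receptor (Homo sapiens), read by cAMP accumulation (a higher number here means a weaker inhibitor, a lower number a stronger inhibitor), compound 2 gives 7400 nM. In the same assay compound 1 gives 4100 nM, and the gap between the two numbers lies within the scatter, so the two compounds cannot be told apart on these data. Compound 3 `O=C(Nc1nn[nH]n1)c1ccc(Cc2cn(-c3ccc(OC(F)(F)F)cc3)nc2C2CCCCC2)cc1` differs from compound 2 by 2H-tetrazol-5-yl in place of 2-carboxyethyl on an amide-type nitrogen. Among the measured compounds shown here, no measured pair carries this change, so its effect in this assay is unknown. For the measured compounds named here, the amide link and the remainder of compound 2 are kept unchanged, and the only comparison available, compound 1 against compound 2, itself stays within the scatter. Compound 3 is therefore expected to show no step beyond the scatter, a 1.2-fold lower number from compound 2 to compound 3 (0.09 log units; within the scatter). For compound 3 the estimate in this assay is 6000 nM, with a range from 1500 nM to 25000 nM.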

Compound 3, half-maximal inhibitory concentration: > 10000 nM
Compound 3: a limit, no number (the forecaster's own chance of this, stated with the estimate: 15%); middle value at least 1.6-fold (0.22 log units) from the limit.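

In this assay compound 3 gives > 10000 nM, which is a limit of the assay and not a number. Among the compounds shown here, this is the first direct reading at the amide-type nitrogen: 2H-tetrazol-5-yl in place of 2-carboxyethyl gives an at least 1.3-fold higher number from compound 2 to compound 3 (0.13 log units; that floor lies within the scatter), so the change brings no sign of a stronger inhibitor, while the true size of the step cannot be read. The reading of this change rests on a single limit: the limit of > 10000 nM in this assay, at which 1 of the 3 values shown sits.

The compounds shown leave open how far compound 3 lies from compound 2, and whether any group on this nitrogen gives a lower number than 2-carboxyethyl. A longer chain ending in a carboxylic acid, or a chain ending in an amine, at the same place would test whether the chain itself matters.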